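Phenyl for pyridinylmethyl on sulfur in an antiproliferative series

The source may report more compounds than this note shows. Statements on the series, on what has been measured and on what is new or still open speak of the compounds shown alone.

Three compounds were measured in a functional assay on HCC827 cells (Homo sapiens) for antiproliferative activity, read by MTT assay, with a stated time of 72 h; on this read-out higher numbers stand for weaker inhibition and lower numbers for stronger inhibition. Compound 1 `CN1CCN(c2ccc(Nc3ncc4nc(SCc5cccnc5)n(C5CC5)c4n3)cc2)CC1` gives 8830 nM, compound 2 `CN1CCN(c2ccc(Nc3ncc4nc([S+]([O-])Cc5cccnc5)n(C5CCCC5)c4n3)cc2)CC1` gives 2350 nM, and compound 3 `CN1CCN(c2ccc(Nc3ncc4nc([S+]([O-])c5ccccc5)n(C5CCCC5)c4n3)cc2)CC1` gives 64.7 nM. Compound 1 and compound 2 differ in more than one place, and the difference between the two cores is not broken down here. Between compound 2 and compound 3 the change is phenyl in place of (pyridin-3-yl)methyl on a sulfur, and it made a 36-fold lower number from compound 2 to compound 3 (1.56 log units; beyond the scatter). Compound 4 `CN1CCN(c2ccc(Nc3ncc4nc(Sc5ccccc5)n(C5CC5)c4n3)cc2)CC1` carries the same kind of change on the core of compound 1, namely (phenyl in place of (pyridin-3-yl)methyl on a sulfur). The sulfur in compound 1 has only an aromatic carbon as its other neighbour, whereas in compound 2 it has an aromatic carbon and an oxygen, so the surroundings of the place are not the same. Compound 4 is expected to show a 20-fold lower number from compound 1 to compound 4 (1.29 log units; beyond the scatter), somewhat smaller than the earlier step, resting on a 36-fold lower number from compound 2 to compound 3 (1.56 log units; beyond the scatter). The estimate for compound 4 in this assay is 450 nM, expected to lie between 100 nM and 2000 nM.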

Compound 4, half-maximal inhibitory concentration: 305 nM
Estimate against measurement, compound 4: 1.5-fold (0.17 log units) above; low and high end bracket the measured number.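

In this assay, phenyl in place of (pyridin-3-yl)methyl on a sulfur gave a 29-fold lower number from compound 1 to compound 4 (1.46 log units; beyond the scatter), so the change carried over to the core of compound 1 with much the same size as before: the same change on two cores in this assay, a 36-fold lower number (1.56 log units; beyond the scatter) from compound 2 to compound 3 and a 29-fold lower number (1.46 log units; beyond the scatter) from compound 1 to compound 4, 1.3-fold (0.10 log units) apart, within the scatter of two such steps The agreement holds even though the sulfur bears an oxygen in compound 2 and compound 3 but not in compound 1 and compound 4. Among these compounds, it rests on only two pairs, however, and does not show that the change would carry the same size to any other core.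

The change alters the ring and the link to the sulfur together, so which of them accounts for the step remains open. A benzyl or a pyridin-3-yl group on the sulfur would separate the two.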